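Chloro for fluoro on a benzyl triazole linked dithiocarbamate

A few compounds are considered here, and "the series" means these few. Any claim that something is new, unique, unknown or untested is made for them only; others in the source may bear on it.

Compound 1 `Cc1ccc(/C=C2\CN(C(=S)SCc3cn(Cc4ccccc4F)nn3)C/C(=C\c3ccc(C)cc3)C2=O)cc1`: 91500 nM
Compound 2 `COc1ccc(/C=C2\CN(Cc3cn(Cc4ccccc4Cl)nn3)C/C(=C\c3ccc(OC)cc3)C2=O)cc1`: > 100000 nM, a limit of the assay.
Compound 3 `COc1ccc(/C=C2\CN(Cc3cn(Cc4ccccc4F)nn3)C/C(=C\c3ccc(OC)cc3)C2=O)cc1`: 67200 nM

In a functional assay on MDA-MB-231 cells (Homo sapiens) for cytotoxicity, read by MTT assay, with a stated time of 24 h (a lower number here means a stronger inhibitor, a higher number a weaker inhibitor), compound 1 gives 91500 nM, and compound 3 gives 67200 nM; these two numbers lie within the scatter of each other. For compound 2 the assay reports only a limit, (the limit of > 100000 nM in this assay, at which 1 of the 3 values shown sits). The step of an at least 1.4-fold higher number from compound 3 to compound 2 (0.17 log units; that floor lies within the scatter) goes with the change (chloro in place of fluoro on an aromatic carbon). How the core of compound 1 differs from the core of compound 3 is not broken down here.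

Compound 4 `Cc1ccc(/C=C2\CN(C(=S)SCc3cn(Cc4ccccc4Cl)nn3)C/C(=C\c3ccc(C)cc3)C2=O)cc1` differs from compound 1 by the same change, (chloro in place of fluoro on an aromatic carbon), made at the same place. Because the measured step of an at least 1.4-fold higher number from compound 3 to compound 2 (0.17 log units; that floor lies within the scatter) gave only a floor that lies within the scatter, the step of a 1.3-fold higher number from compound 1 to compound 4 (0.10 log units; within the scatter) is expected to be small and in the same direction, so compound 4 is expected to reach or pass the limit of the assay. Compound 4 is estimated at 115000 nM, between 60000 nM and 250000 nM.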

Compound 4, half-maximal inhibitory concentration: 93200 nM
Compound 4: middle estimate off by 1.2-fold (0.09 log units), on the high side; low and high end bracket the measured number.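

In this assay, chloro in place of fluoro, read as 2-fluorobenzyl to 2-chlorobenzyl on the core of compound 1, gives a 1.0-fold higher number from compound 1 to compound 4 (0.01 log units; within the scatter), a step within the scatter. Set beside the earlier step on the other core, the result reads: the same change on two cores in this assay, an at least 1.4-fold higher number (0.17 log units; that floor lies within the scatter) from compound 3 to compound 2 and a 1.0-fold higher number (0.01 log units; within the scatter) from compound 1 to compound 4; the limit leaves it open whether they differ. Going by these compounds alone, this shows no sizeable step on the core of compound 1, but it does not show that the change carries over equally from one core to the other, as compound 2 stands only at a limit of the assay: the limit of > 100000 nM in this assay, at which 1 of the 4 values shown sits.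

The compounds shown carry only fluoro or chloro at this place, which leaves open how a bromo, a methyl or a nitrile there would compare in this assay. Also open, from the compounds shown here alone, is what each separate difference between the core of compound 1 and the core of compound 3 contributes, since those two cores differ in more than one place.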